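Swapping one aromatic substituent in a cytotoxicity series

The compounds below may be only part of what the source reports. "The series", "measured", "known", "first", "only" and "open" are said of these compounds alone.

Three compounds share one core and differ in two side groups. Compound 1 `Cc1ccccc1-c1nn(-c2ccc(C(F)(F)F)cc2)cc1CNCCN1CCN(C)CC1`, compound 2 `Cc1ccccc1-c1nn(-c2ccc(F)cc2F)cc1CNC1CCN(S(C)(=O)=O)CC1` and compound 3 `COc1ccc(-n2cc(CNCCN3CCN(C)CC3)c(-c3ccccc3C)n2)cc1` were tested in an ADME assay on Huh-7 cells (Homo sapiens) for cytotoxicity; a higher number here means that more compound is tolerated, a lower number that less compound is tolerated. Compound 1 gives 11000 nM. Compound 2 reaches only the limit of the assay, > 20000 nM. Compound 3 likewise reaches only a limit, > 20000 nM, so its position is known only as a floor, and one of the other two values is such a floor as well. Among the compounds with values here, the one step measured between compounds that differ in a single place, an at least 1.8-fold higher number from compound 1 to compound 3 (0.25 log units; that floor lies within the scatter), has a floor that lies within the scatter, so it cannot be called a real change.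

Compound 4 `Cc1ccccc1-c1nn(-c2ccc(F)cc2F)cc1CNCCN1CCN(C)CC1` has not been tested. It differs from compound 3 in a single place: 2,4-difluorophenyl in place of 4-methoxyphenyl on an aromatic nitrogen. Within the data shown here, no measured step covers this exact swap. Compound 2 carries the same 2,4-difluorophenyl group with a different amine chain and reaches only a limit, and compound 3 does too. The number for compound 4 is therefore expected to stay near the ceiling of this assay, with no step beyond the scatter, because the limit of > 20000 nM in this assay, at which 2 of the 3 values shown sit, is where both of its closest relatives sit. Compound 4 is estimated at 22000 nM, between 9000 nM and 45000 nM, which means an expected step that the limit leaves unreadable from compound 3 to compound 4.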

Compound 4, half-maximal cytotoxic concentration: > 20000 nM
Compound 4 gave a limit, no number; the forecaster's own chance of this, stated with the estimate: 65%; the middle value does not contradict the limit.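

In this assay compound 4 gives a limit and not a number, so a second group on the aromatic nitrogen, 2,4-difluorophenyl in place of 4-methoxyphenyl, leaves the 2-(4-methylpiperazin-1-yl)ethyl series at a limit. The steps that join compound 4 to compound 3 and to compound 2 cannot be read, as both ends of each are limits. The only readable new step, an at least 1.8-fold higher number from compound 1 to compound 4 (0.25 log units; that floor lies within the scatter), is a swap at this same position, 2,4-difluorophenyl in place of 4-(trifluoromethyl)phenyl, and like the methoxy step it cannot be called a real change, so this position has not yet shown a change beyond the scatter, and most of the series rests on one value that is not a true number: the limit of > 20000 nM in this assay, at which 3 of the 4 values shown sit.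

Within the data shown here, compound 1 at 11000 nM is the only one with a true number. From the compounds shown here alone, whether compound 1 really differs from compound 3 and compound 4 stays open, and so does how much of those two is tolerated past the limit. Also open, going by these compounds, is how a plain phenyl or a 4-chlorophenyl group on that aromatic nitrogen would behave with the same chain.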